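Furan-3-yl in place of the ring of compound 2

The compounds below may be only part of what the source reports. "The series", "measured", "known", "first", "only" and "open" are said of these compounds alone.

Values in a functional assay on HT-29 cells (Homo sapiens) for antiproliferative activity, read by XTT assay, with a stated time of 72 h; on this read-out lower numbers stand for stronger inhibition and higher numbers for weaker inhibition:
- compound 1 `C=C(C)CCC[C@]1(C)C2=CCC[C@](C)(CC(=O)c3ccoc3)[C@H]2CC[C@H]1C`: > 100000 nM, a limit
- compound 2 `C=C(C)CCC[C@]1(C)C2=CCC[C@](C)(C[C@@H](O)C3=CC(=O)OC3O)[C@H]2CC[C@H]1C`: 2300 nM
- compound 3 `C=C(C)CC[C@]1(C)C2=CCC[C@](C)(C[C@@H](O)C3=CC(=O)OC3O)[C@H]2CC[C@H]1C`: 3600 nM

Going by the values given here, compound 2 and compound 3 are the only two that give a number, and these lie within the scatter of each other: a 1.6-fold higher number from compound 2 to compound 3 (0.19 log units; within the scatter). That step changes a chain, not the ring, so it says little about the change considered here.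

Compound 4 `C=C(C)CCC[C@]1(C)C2=CCC[C@](C)(C[C@@H](O)c3ccoc3)[C@H]2CC[C@H]1C` has not yet been measured. Its difference from compound 2 is a group of 5 heavy atoms (4 carbon, 1 oxygen; one five-membered aromatic ring with 1 hetero atom) in place of a group of 7 heavy atoms (4 carbon, 3 oxygen; one five-membered non-aromatic ring with 1 hetero atom), on a saturated chain carbon bound to an oxygen on a saturated carbon and a saturated chain carbon. The step that bears on this is an at least 43-fold lower number from compound 1 to compound 2 (1.63 log units; beyond the scatter), which exchanged a five-membered aromatic ring for a five-membered non-aromatic ring, the reverse of the exchange here. Compound 1 enters that step only as a limit. A large step towards a higher number is therefore expected in this assay, and the result may itself be only a limit. The expected step is a 17-fold higher number from compound 2 to compound 4 (1.24 log units; beyond the scatter). The estimate for compound 4 is 40000 nM, with an expected range of 12000 nM to 100000 nM.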

Compound 4, half-maximal inhibitory concentration: 63100 nM
Estimate against measurement, compound 4: 1.6-fold (0.20 log units) below; measured number inside the range.
By their numbers in this assay, from the lowest: compounds 2 and 3 (each within the scatter of the next); then compound 4. At a limit, above all of these: compound 1.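

In this assay, the exchange of the ring now has a number at both ends, a 27-fold higher number from compound 2 to compound 4 (1.44 log units; beyond the scatter), and the hydroxy-bearing carbon is the same in both compounds, so this loss belongs to furan-3-yl in place of the ring of compound 2 alone, whereas the earlier step from compound 1 also changed that carbon. The other new step, an at least 1.5-fold lower number from compound 1 to compound 4 (0.19 log units; that floor lies within the scatter), gives only a floor, so the change from (furan-3-yl)carbonyl to (furan-3-yl)(hydroxy)methyl cannot be sized. Compound 1 gives a limit, not a number: the limit of > 100000 nM in this assay, at which 1 of the 4 values shown sits.

From the compounds shown here alone, whether a carboxylic acid or an amine on this chain carbon could take the place of the ring of compound 2 stays open. Going by these compounds alone, the 1-methylethenyl chain end of compound 3 is also seen only with that ring, never with furan-3-yl.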